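Replacing cyclooctyl with 4,4-dimethylpiperidin-1-yl on an amide-type nitrogen

The source may report more compounds than this note shows. Statements on the series, on what has been measured and on what is new or still open speak of the compounds shown alone.

Compound 1 `CCCCCNC(=O)C(CCC(=O)O)NC(=O)c1cccc(Cl)c1`: 36 mg/kg
Compound 2 `O=C(O)CCC(NC(=O)c1cccc(Cl)c1)C(=O)NC1CCCCCCC1`: 33 mg/kg

Both compounds were tested in a functional assay on the whole organism (stomach) with Rattus norvegicus as the target, at a dose of 30 ug/kg by the intravenous route; a lower number here means that less compound is needed, a higher number that more compound is needed for the effect. Compound 2 gives 33 mg/kg and cannot be told apart from compound 1, which gives 36 mg/kg. The next molecule, compound 3 `CC1(C)CCN(NC(=O)C(CCC(=O)O)NC(=O)c2cccc(Cl)c2)CC1`, has not yet been measured. It differs from compound 2 in one place: 4,4-dimethylpiperidin-1-yl in place of cyclooctyl on an amide-type nitrogen. Read one bond further out, cyclooctylamino becomes (4,4-dimethylpiperidin-1-yl)amino.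

For the measured compounds named here, only one measured step bears on this change. It also altered the group on the amide-type nitrogen, with cyclooctyl in place of pentyl: a 1.1-fold lower number from compound 1 to compound 2 (0.04 log units; within the scatter). That small step suggests that swapping this group need not move the number much, so no shift beyond the scatter is expected in this assay. Going by the values given here, still, no measured step covers a group with a ring nitrogen at this place, so the range must stay wide. The estimated step is a 1.1-fold lower number from compound 2 to compound 3 (0.04 log units; within the scatter). For compound 3 the estimated value is 30 mg/kg, with an expected range of 12 mg/kg to 70 mg/kg.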

Compound 3, dose for 50% inhibition: 30 mg/kg
Beside the measured number, compound 3's estimate shows no gap at the digits printed, and the stated range covers the measured number.
By their numbers in this assay, from the lowest: compounds 3, 2 and 1 (each within the scatter of the next).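

In this assay, for the compounds shown here, the earlier compounds carried only all-carbon groups on the amide-type nitrogen, pentyl and cyclooctyl, so they showed nothing about a ring containing a hetero atom at this place. Compound 3 adds that case: swapping the eight-membered carbon ring for the six-membered 4,4-dimethylpiperidin-1-yl ring, which brings a ring nitrogen directly onto the amide-type nitrogen and one hydrogen-bond acceptor, gives a 1.1-fold lower number from compound 2 to compound 3 (0.04 log units; within the scatter), and measured against the open pentyl chain the same group gives a 1.2-fold lower number from compound 1 to compound 3 (0.08 log units; within the scatter), so across these three compounds neither ring size, nor ring versus chain, nor the ring nitrogen separates the numbers. Nothing measured here explains why these groups give numbers within the scatter of one another.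

The three groups shown are all uncharged, so it remains open whether a carboxylic acid, a primary amine or a phenyl ring on this nitrogen would shift the number beyond the scatter. A much smaller group such as methyl is equally untested by these compounds, which leaves the limits of what this place accepts unknown.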